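Swapping a carboxylic acid for a tert-butyl group

The source may hold more compounds than are shown below. What is called first, only, known or untested is meant among the compounds shown, and "the series" means these compounds.

Measured so far:
compound 1, `COc1cc(C(C)=O)ccc1OCCCN1CCC(C(c2ccc(F)cc2F)c2ccc(F)cc2F)CC1`: 15.9 nM
compound 2, `COc1cc(C(=O)O)ccc1OCCCN1CCC(C(c2ccc(F)cc2)c2ccc(F)cc2)CC1`: 79.4 nM

Of the compounds shown here, two have been measured in a functional assay (aorta) with Oryctolagus cuniculus as the target; a higher number here means weaker binding, a lower number tighter binding. Compound 1 gives 15.9 nM, and compound 2 gives 79.4 nM. Compound 2 therefore stands at the higher of the two numbers, and its gap to compound 1 lies beyond the usual scatter. The two differ in more than one place, so the gap is not tied to any single change.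

Compound 3, `CC(C)(C)c1ccc(OCCCN2CCC(C(c3ccc(F)cc3)c3ccc(F)cc3)CC2)cc1`, is the unmeasured compound. It arises from compound 2 by the change (4-(tert-butyl)phenyl in place of 4-carboxy-2-methoxyphenyl on an oxygen on a saturated carbon). With this, the carboxylic acid and the methoxy group leave, and an all-carbon group enters. Among the measured compounds shown here, no measured pair shows such an exchange, so the expectation rests on the two values alone and on the nature of the change.

The step from compound 2 to compound 3 is expected to be a 5.0-fold lower number from compound 2 to compound 3 (0.70 log units; beyond the scatter), toward a lower number. For compound 3 the estimated value in this assay is 16 nM, expected to lie between 4 nM and 60 nM.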

Compound 3, dissociation constant: 1 nM
Estimate against measurement, compound 3: 16-fold (1.20 log units) above; the measured number lies below the stated range.
By their numbers in this assay, from the lowest: compound 3; then compound 1; then compound 2.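

In this assay, the group on this oxygen turns out to matter a great deal: putting 4-(tert-butyl)phenyl in place of 4-carboxy-2-methoxyphenyl gives a 79-fold lower number from compound 2 to compound 3 (1.90 log units; beyond the scatter). Among the compounds shown here, the earlier compounds differed in more than one place, so this is the first gap that can be tied to a single change. It also shows that tight binding here does not need the carboxylic acid or the methoxy group, since the entering group is all carbon, with no hydrogen-bond donors or acceptors, and nothing shown explains the size of the step.

On these data alone, the change removes the carboxylic acid and the methoxy group and adds the tert-butyl group all at once, so the share of each in the step remains unknown. As far as these compounds go, it also remains open whether an isopropyl group or a primary amide in the place of the tert-butyl group would keep the number this low.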